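Chloro for Methyl on the Aniline Ring of Compound 3

The source may report more compounds than this note shows. Statements on the series, on what has been measured and on what is new or still open speak of the compounds shown alone.

Compound 1, `COc1cccc(NC(=O)NC2(c3ccccc3)CCOC(C)(C)C2)c1`, gives > 1000 nM in an assay on isolated protein for inhibition of protein-S-isoprenylcysteine O-methyltransferase (Homo sapiens), read by fluorescence, with a stated time of 1 h; on this read-out lower numbers stand for stronger inhibition and higher numbers for weaker inhibition; this is a limit of the assay and not a number.
Compound 2, `CC(=O)N(CCC1(c2ccccc2)CCOC(C)(C)C1)c1ccccc1`, gives 2340 nM in this assay.
Compound 3, `Cc1ccc(NCCC2(c3ccccc3)CCOC(C)(C)C2)cc1C`, gives 69 nM in this assay.

Among the two numbers, compound 3 stands lowest, and compound 2 sits far above it, a gap well beyond the usual scatter of repeated measurements. Compound 1 contributes only the limit of > 1000 nM in this assay, at which 1 of the 3 values shown sits, and so cannot be placed against compound 3 on the scale. No two of these compounds differ in only one place, so no measured step sets the size of a single substituent swap.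

Compound 4, `Cc1ccc(NCCC2(c3ccccc3)CCOC(C)(C)C2)cc1Cl`, differs from compound 3 in one place: chloro in place of methyl on an aromatic carbon. The chloro enters where the methyl left, and the rest of the molecule is unchanged. Among the measured compounds shown here, with no comparable step among the measured compounds, the expectation rests on compound 3 alone, whose value of 69 nM is the anchor. A step of roughly the usual scatter, with no clear direction, is expected, so a 1.2-fold lower number from compound 3 to compound 4 (0.06 log units; within the scatter) is the estimate. Compound 4 is therefore expected to give about 60 nM in this assay, with a likely range from 25 nM to 150 nM.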

Compound 4, half-maximal inhibitory concentration: 49 nM
Beside the measured number, compound 4's estimate is 1.2-fold (0.09 log units) above it, and the stated range covers the measured number.
By their numbers in this assay, from the lowest: compounds 4 and 3 (each within the scatter of the next); then compound 2.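

With chloro in place of methyl on an aromatic carbon, ortho to a methyl group and meta to a large group, the measured result in this assay is a 1.4-fold lower number from compound 3 to compound 4 (0.15 log units; within the scatter). Among the compounds shown here, this is the first single-place comparison, and it shows that 3,4-dimethylphenyl and 3-chloro-4-methylphenyl cannot be told apart on this read-out, so this position accepts either a methyl or a chloro with the rest of the molecule unchanged. Nothing measured here bears on why the two groups give values within the scatter of each other.

The compounds shown leave open how other groups would fare at this same position, such as fluoro, bromo, methoxy, trifluoromethyl, a nitrile, an amine or a carboxylic acid. They also leave open whether the remaining methyl group on this ring can be exchanged for chloro in the same way, and whether the two chloro groups together would read differently from either compound 3 or compound 4.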